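Moving a Fluorine on the Sulfonyl Ring

The source may hold more compounds than are shown below. What is called first, only, known or untested is meant among the compounds shown, and "the series" means these compounds.

Compound 3 `O=C(NCc1ccc(S(=O)(=O)c2cc(F)cc(F)c2)cc1)c1cc2cnccc2[nH]1` gives 82% in an ADME assay on microsomes from liver (Homo sapiens) for metabolic stability, read by LC-MS, with a stated time of 30 min, tested at 1 uM (on this read-out higher numbers stand for a more stable compound and lower numbers for a less stable compound), the highest of the three numbers seen. Compound 1 `O=C(NCc1ccc(S(=O)(=O)c2cc(F)cc(F)c2)cc1)c1cc2ccncc2o1` gives 77%, and the step of a number 5 percentage points higher from compound 1 to compound 3 (within the scatter) swaps a group on a carbonyl carbon. Compound 2 `Cc1cccc(S(=O)(=O)c2ccc(CNC(=O)c3cc4cnccc4[nH]3)cc2)c1` gives 49%, and the step of a number 33 percentage points higher from compound 2 to compound 3 (beyond the scatter) swaps the group on the sulfonyl sulfur. Compound 4 `O=C(NCc1ccc(S(=O)(=O)c2ccc(F)c(F)c2)cc1)c1cc2cnccc2[nH]1` differs from compound 3 at that same sulfonyl sulfur: 3,4-difluorophenyl in place of 3,5-difluorophenyl on a sulfonyl sulfur. For the measured compounds named here, only the step from compound 2 to compound 3 bears on this place, and it was large; here, however, the two compounds have the same atoms, joined differently. The expected step is a number 6 percentage points lower from compound 3 to compound 4 (within the scatter), within the scatter. Compound 4 is estimated to give 76%, between 60% and 90%.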

Compound 4, percent of the compound remaining: 100%
For compound 4 the middle estimate is 24 percentage points below the measured one, outside the stated range (above it).
By their numbers in this assay, from the lowest: compound 2; then compounds 1 and 3 (each within the scatter of the next); then compound 4.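

For the compounds shown here, earlier, the only change at this sulfonyl sulfur replaced one group with a different one. Here the same atoms, joined differently, still matter: 3,4-difluorophenyl in place of 3,5-difluorophenyl gives a number 18 percentage points higher from compound 3 to compound 4 (beyond the scatter) in this assay with no atom added or lost. Against 3-methylphenyl, the same group gives a number 51 percentage points higher from compound 2 to compound 4 (beyond the scatter) and so goes further than the earlier change at this place. Nothing available explains why this arrangement of fluorines does better. From the compounds shown here alone, whether a chlorine or a methoxy group in place of a fluorine would do as well stays open, as does whether the gain carries over to the core of compound 1.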